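A Carboxypyridine Variant in a Bombesin Receptor Agonist Series

This account rests on a few compounds, and the source may have more. Where it says the series, first, only, none or still open, it means among the compounds named here.

Compound 1, `CCC(C)(C)Cc1c[nH]c(CCc2ccc(-c3cccc(N)n3)cc2)n1`: in a functional assay on HEK293 cells for agonist activity at Bombesin receptor subtype-3 (Homo sapiens), read by luminescence and calcium flux, with a stated time of 10 min (a lower number here means that less compound is needed, a higher number that more compound is needed for the effect), compound 1 gives 37 nM.
Compound 2, `CCC(C)(C)Cc1c[nH]c(CCc2ccc(-n3cccn3)cc2)n1`: in this assay compound 2 gives 135 nM.

Among the compounds with values here, compound 2 holds the highest of the two numbers so far, and the single measured step, a 3.6-fold higher number from compound 1 to compound 2 (0.56 log units; beyond the scatter), is the only comparison available. Compound 3, `CCC(C)(C)Cc1c[nH]c(CCc2ccc(-c3cccnc3C(=O)O)cc2)n1`, has not yet been measured. It differs from compound 2 in one place: 2-carboxypyridin-3-yl in place of 1H-pyrazol-1-yl on an aromatic carbon.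

Within the data shown here, the one step that bears on this change replaced a six-membered aromatic ring carrying an amino group with a five-membered ring and raised the number modestly. Compound 3 restores a six-membered ring with a hydrogen-bond donor, but a carboxylic acid is a different group from an amine, so that step is only a loose guide. Compound 3 is therefore expected to land near compound 2, with a step of about a 1.1-fold lower number from compound 2 to compound 3 (0.05 log units; within the scatter), and no change beyond the scatter is predicted with confidence. The estimate for compound 3 in this assay is 120 nM, within a range from 25 nM to 600 nM.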

Compound 3, half-maximal effective concentration: 1260 nM
The estimate for compound 3 lay 11-fold (1.02 log units) below the measured number, and the stated range ends below it.
By their numbers in this assay, from the lowest: compound 1; then compound 2; then compound 3.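

The wider span of numbers shows that this place, on an aromatic carbon para to a large group, tolerates these three groups very unequally: the change to 2-carboxypyridin-3-yl gives a 9.3-fold higher number from compound 2 to compound 3 (0.97 log units; beyond the scatter) and, against the best of the three, a 34-fold higher number from compound 1 to compound 3 (1.53 log units; beyond the scatter) in this assay. It also shows that a six-membered aromatic ring with one hetero atom does not by itself keep the number low, since compound 1 and compound 3 both carry such a ring and stand at opposite ends of the series, with the five-membered ring of compound 2 between them. Within the data shown here, nothing in the data speaks to why the carboxypyridine group raises the number so far.

The step changes the ring and adds the carboxylic acid together, so the compounds shown cannot say how much of the rise belongs to each. A plain pyridin-3-yl group, or a methyl ester or primary amide in place of the carboxylic acid, would pull these two parts apart, and the same holds for the amine of compound 1, whose own share in the low number remains unseparated from its ring.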